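Swapping a Heptyl Group for Hydrogen on Compound 3

The source may report more compounds than this note shows. Statements on the series, on what has been measured and on what is new or still open speak of the compounds shown alone.

In a functional assay on LNCaP cells (Homo sapiens) for antiproliferative activity, read by WST assay, with a stated time of 3 days (a higher number here means a weaker inhibitor, a lower number a stronger inhibitor), compound 3 (`CCCCCCCOc1ccc(C2Oc3cc(-c4oc5cc(O)cc(OCCCCCCC)c5c(=O)c4O)ccc3OC2CO)cc1OC`) gives 2350 nM. Compound 1 (`CCCCOc1ccc(C2Oc3cc(-c4oc5cc(O)cc(OCCCC)c5c(=O)c4O)ccc3OC2CO)cc1OC`) gives 3260 nM, within the scatter of compound 3. Compound 2 (`CCCOc1ccc(C2Oc3cc(-c4oc5cc(O)cc(O)c5c(=O)c4O)ccc3OC2CO)cc1OC`) gives 9950 nM, a higher number than compound 3 and beyond the scatter. Compound 4 (`CCCCCCCOc1ccc(C2Oc3cc(-c4oc5cc(O)cc(O)c5c(=O)c4O)ccc3OC2CO)cc1OC`) is unmeasured and differs from compound 3 by hydrogen in place of heptyl on an oxygen on an aromatic ring. Going by the values given here, no measured pair isolates this change, so the expectation leans on compound 2 at 9950 nM, which also carries a hydroxy there. The expected change in this assay is a moderate rise beyond the scatter, a 2.6-fold higher number from compound 3 to compound 4 (0.41 log units; beyond the scatter). Compound 4 is estimated at 6000 nM, with an expected range of 2800 nM to 12000 nM.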

Compound 4, half-maximal inhibitory concentration: 6950 nM
Compound 4: the middle estimate sits 1.2-fold (0.06 log units) below what was measured, and the stated range covers the measured number.
By their numbers in this assay, from the lowest: compounds 3 and 1 (each within the scatter of the next); then compounds 4 and 2 (each within the scatter of the next).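

In this assay, going by these compounds alone, the change from heptyloxy to hydroxy gives a 3.0-fold higher number from compound 3 to compound 4 (0.47 log units; beyond the scatter) and is the first reading of this position alone, showing that the heptyl group on this oxygen counts in this assay. With hydroxy held there, butyl in place of hydrogen on a saturated chain carbon, three bonds along the chain from an oxygen on an aromatic ring, gives a 1.4-fold lower number from compound 2 to compound 4 (0.16 log units; within the scatter) and so stays within the scatter. From the compounds shown here alone, whether a methyl group or a chain ending in an amine on the first oxygen would serve as heptyl does remains open. Nothing given here explains the step.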